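The compounds below may be only part of what the source reports. "The series", "measured", "known", "first", "only" and "open" are said of these compounds alone.

Measured compounds:
compound 1 `O=c1c2ccccc2c(-c2cccnc2)nn1CC1CCCCC1`: 98%
compound 2 `CC(=O)OCCn1nc(-c2cccnc2)c2ccccc2c1=O`: 32%
compound 3 `CCOC(=O)Cn1nc(-c2cccnc2)c2ccccc2c1=O`: 28%

In an assay on isolated protein (Oryctolagus cuniculus) with Thromboxane-A synthase (Homo sapiens) as the target, tested at 1 uM (a higher number here means more inhibition at the concentration tested (going by the name of the read-out), a lower number less inhibition), compound 3 stands lowest of the three, though its gap to compound 2, a number 4 percentage points lower from compound 2 to compound 3 (within the scatter), lies within the scatter, while compound 1 sits far above it, a number 70 percentage points lower from compound 1 to compound 3 (beyond the scatter). Compound 4 `O=C(O)c1ccc(Cn2nc(-c3cccnc3)c3ccccc3c2=O)cc1` differs from compound 3 by 4-carboxyphenyl in place of ethoxycarbonyl on a saturated chain carbon bound to an aromatic nitrogen. Among the measured compounds shown here, no measured step exchanges ethoxycarbonyl for 4-carboxyphenyl, so the nearest guide is that cyclohexyl gave compound 1 its high value, and the large drops a number 66 percentage points lower from compound 1 to compound 2 (beyond the scatter) and a number 70 percentage points lower from compound 1 to compound 3 (beyond the scatter) came when cyclohexyl was exchanged for acetoxymethyl or ethoxycarbonyl. Since 4-carboxyphenyl again brings a ring, a rise is expected, a number 52 percentage points higher from compound 3 to compound 4 (beyond the scatter), though with wide uncertainty. Compound 4 is estimated at 80%, between 45% and 99%.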

Compound 4, a percentage reported as inhibition, at one concentration (the size of the read-out at that concentration, not a potency): 64%
Compound 4: the middle estimate sits 16 percentage points above what was measured; measured number inside the range.
By their numbers in this assay, from the lowest: compounds 3 and 2 (each within the scatter of the next); then compound 4; then compound 1.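

In this assay, 4-carboxyphenyl at this saturated chain carbon bound to an aromatic nitrogen gives a much higher number than the two ringless groups (a number 36 percentage points higher from compound 3 to compound 4 (beyond the scatter); a number 32 percentage points higher from compound 2 to compound 4 (beyond the scatter)). It still falls short of cyclohexyl (a number 34 percentage points lower from compound 1 to compound 4 (beyond the scatter)), so among these four compounds, the presence of a ring does not settle the outcome, and the two ring-bearing groups differ clearly. Nothing available explains these differences. From the compounds shown here alone, what the carboxyl group itself contributes remains open. A plain phenyl, or a phenyl carrying an amine, would help separate its contribution from that of the ring.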